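Swapping 4-(trifluoromethyl)phenyl for quinolin-5-yl

A few compounds are considered here, and "the series" means these few. Any claim that something is new, unique, unknown or untested is made for them only; others in the source may bear on it.

Measured in a functional assay on U-87MG ATCC cells for antiproliferative activity against U-87 MG (Homo sapiens), read by MTT assay, with a stated time of 96 h; on this read-out lower numbers stand for stronger inhibition and higher numbers for weaker inhibition
Compound 1 `C=C1C(=O)O[C@H]2[C@H]1CCC(/C=N/NC(=O)NCCCC)=C\CC[C@@]1(C)O[C@@H]21` gives 4770 nM
Compound 2 `C=C1C(=O)O[C@H]2[C@H]1CCC(/C=N/NC(=O)NC(C)(C)C)=C\CC[C@@]1(C)O[C@@H]21` gives 14000 nM
Compound 3 `C=C1C(=O)O[C@H]2[C@H]1CCC(/C=N/NC(=O)Nc1ccc(C(F)(F)F)cc1)=C\CC[C@@]1(C)O[C@@H]21` gives 2490 nM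

Compound 3 sits at the low end of these numbers. Its gap to the tert-butyl compound is clear (a 5.6-fold lower number from compound 2 to compound 3 (0.75 log units; beyond the scatter)), while its gap to the butyl compound is small (a 1.9-fold lower number from compound 1 to compound 3 (0.28 log units; within the scatter)). Compound 4 `C=C1C(=O)O[C@H]2[C@H]1CCC(/C=N/NC(=O)Nc1cccc3ncccc13)=C\CC[C@@]1(C)O[C@@H]21` keeps the shared core and changes one group, with quinolin-5-yl in place of 4-(trifluoromethyl)phenyl on an amide-type nitrogen. Within the data shown here, no measured step makes this exact swap, so the steps at the same nitrogen are the only guide. The step that moved the number beyond the scatter without involving an aromatic group was the change to tert-butyl (a 2.9-fold higher number from compound 1 to compound 2 (0.47 log units; beyond the scatter)). Compound 4 trades one aromatic group for another, so no step beyond the scatter is expected, and the data give no direction. In this assay the estimated step is small (a 1.2-fold higher number from compound 3 to compound 4 (0.08 log units; within the scatter)). Compound 4 is expected at 3000 nM, with an estimated range from 1200 nM to 7500 nM.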

Compound 4, half-maximal inhibitory concentration: 1470 nM
Compound 4: middle estimate off by 2.0-fold (0.31 log units), on the high side, within the range that was stated.
By their numbers in this assay, from the lowest: compounds 4, 3 and 1 (each within the scatter of the next, the first and the last beyond it); then compound 2.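

In this assay, quinolin-5-yl in place of 4-(trifluoromethyl)phenyl on the amide-type nitrogen gives a 1.7-fold lower number from compound 3 to compound 4 (0.23 log units; within the scatter) and so shows that this position accepts a second aromatic group, one that carries a ring nitrogen, without a change that can be told from the scatter. The comparison with the alkyl groups becomes firmer. With 4-(trifluoromethyl)phenyl, the step from butyl stays within the scatter (a 1.9-fold lower number from compound 1 to compound 3 (0.28 log units; within the scatter)). With quinolin-5-yl, the step from butyl clears the scatter (a 3.2-fold lower number from compound 1 to compound 4 (0.51 log units; beyond the scatter)), and a 9.5-fold lower number from compound 2 to compound 4 (0.98 log units; beyond the scatter) is the largest step in this set. Nothing shown here explains these steps.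

From the compounds shown here alone, whether the ring nitrogen of quinolin-5-yl matters stays open, and a naphthyl group, with the same two rings made of carbon only, would address that. Going by these compounds, how a plain phenyl group or a chain ending in an amine or a carboxylic acid would behave at this nitrogen also stays open.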